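Three-aryl substituents on the shared core; fourth one pending

A few compounds are considered here, and "the series" means these few. Any claim that something is new, unique, unknown or untested is made for them only; others in the source may bear on it.

Measured so far in an assay for binding affinity to dual specificity mitogen-activated protein kinase kinase 4 (Homo sapiens), read by KINOMEscan, tested at 100 nM; a higher number here means a weaker effect of the compound at the concentration tested, a lower number a stronger effect:
- compound 1 `CCCS(=O)(=O)Nc1ccc(F)c(C(=O)c2n[nH]c3ncc(-c4cccc(O)c4)cc23)c1F`: 2.2%
- compound 2 `CCCS(=O)(=O)Nc1ccc(F)c(C(=O)c2n[nH]c3ncc(-c4cccc(N)c4)cc23)c1F`: 1.6%
- compound 3 `CCCS(=O)(=O)Nc1ccc(F)c(C(=O)c2n[nH]c3ncc(-c4ccc(C(F)(F)F)cc4)cc23)c1F`: 29%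

Compound 1 stands second highest of the three numbers; its nearest neighbour is compound 2, a number 0.6 percentage points lower from compound 1 to compound 2 (within the scatter), and its furthest is compound 3, a number 26.8 percentage points higher from compound 1 to compound 3 (beyond the scatter). The other step, a number 27.4 percentage points higher from compound 2 to compound 3 (beyond the scatter), runs the same way.

Compound 4 `CCCS(=O)(=O)Nc1ccc(F)c(C(=O)c2n[nH]c3ncc(-c4ccc(S(N)(=O)=O)cc4)cc23)c1F` is not yet measured. It differs from compound 1 in one place: 4-sulfamoylphenyl in place of 3-hydroxyphenyl on an aromatic carbon. Of the measured steps, a number 26.8 percentage points higher from compound 1 to compound 3 (beyond the scatter) bears most directly on it, since the same group leaves and another 4-substituted phenyl enters; a number 27.4 percentage points higher from compound 2 to compound 3 (beyond the scatter) points the same way. Among the measured compounds shown here, no step with 4-sulfamoylphenyl is known, so the size is uncertain. In this assay the estimated step is a number 5.8 percentage points higher from compound 1 to compound 4 (within the scatter). This would be smaller than the step to compound 3. For compound 4 the estimate is 8%, with a range of 1.5% to 35%.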

Compound 4, a percentage reported as activity, at one concentration (the size of the read-out at that concentration, not a potency): 0.25%
Beside the measured number, compound 4's estimate is 7.8 percentage points above it, and the stated range ends above it.
By their numbers in this assay, from the lowest: compounds 4, 2 and 1 (each within the scatter of the next); then compound 3.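

In this assay the weaker read-out of compound 3 does not extend to every 4-substituted phenyl at this position: sulfamoyl in place of trifluoromethyl gives a number 28.8 percentage points lower from compound 3 to compound 4 (beyond the scatter) and restores a low read-out. Set against the two 3-substituted phenyls, 4-sulfamoylphenyl gives a number 2 percentage points lower from compound 1 to compound 4 (within the scatter) and a number 1.4 percentage points lower from compound 2 to compound 4 (within the scatter), so the three groups cannot be ordered at this single concentration, and a 4-substituted phenyl can read as low as a 3-substituted one. No measurement is available to explain the gap between sulfamoyl and trifluoromethyl.

Going by these compounds, it remains open whether a carboxylic acid or a methylsulfonyl group on the same phenyl carbon would follow sulfamoyl or trifluoromethyl. Also open, on these data alone, is how a trifluoromethyl or sulfamoyl group would read on the phenyl carbon that carries hydroxy in compound 1.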